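Swapping an amide arm for a short ether chain

The source may hold more compounds than are shown below. What is called first, only, known or untested is meant among the compounds shown, and "the series" means these compounds.

For the measured compounds named here, the three compounds measured so far share a core carrying an acrylamide, and they differ in the group hanging from the far aromatic ring. Compound 1 `C=CC(=O)Nc1cccc(Nc2ncnc(Nc3ccc(C(=O)Nc4ccc(C)cn4)cc3)n2)c1` gives 125000 nM in a functional assay on Raji cells (Homo sapiens) for antiproliferative activity, read by CCK-8 assay, with a stated time of 24 h (a lower number here means a stronger inhibitor, a higher number a weaker inhibitor), the highest of the three numbers. Compound 3 `C=CC(=O)Nc1cccc(Nc2nc(Cl)nc(Nc3ccc(Oc4ccccc4)cc3)n2)c1` gives 15700 nM, and compound 2 `C=CC(=O)N1CCc2ccc(Nc3ncnc(Nc4ccc(C(=O)N5CCCCC5)cc4)n3)cc21` gives 2840 nM. Compound 4 `C=CC(=O)Nc1cccc(Nc2ncnc(Nc3ccc(OCCOC)cc3)n2)c1` differs from compound 1 in one place: 2-methoxyethoxy in place of (5-methylpyridin-2-yl)carbamoyl on an aromatic carbon. Going by the values given here, no such step has been measured here, so its size is open; a moderate drop in the number, beyond the scatter, seems plausible, since compound 3 with a different ether-type group reaches 15700 nM. Compound 4 is therefore expected to give about 30000 nM, within roughly 6000 nM to 150000 nM, a step of a 4.2-fold lower number from compound 1 to compound 4 (0.62 log units; beyond the scatter).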

Compound 4, half-maximal inhibitory concentration: 105000 nM
Compound 4: the middle estimate sits 3.5-fold (0.54 log units) below what was measured, within the range that was stated.
By their numbers in this assay, from the lowest: compound 2; then compound 3; then compounds 4 and 1 (each within the scatter of the next).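

In this assay, putting 2-methoxyethoxy in place of (5-methylpyridin-2-yl)carbamoyl gives a 1.2-fold lower number from compound 1 to compound 4 (0.08 log units; within the scatter). At this aromatic carbon, then, a group with a six-membered aromatic ring and a hydrogen-bond donor and a smaller group with neither give numbers that cannot be told apart. Nothing measured here explains this result. As far as these compounds go, whether an amine, a carboxylic acid or a longer chain at this carbon would give a number beyond the scatter stays open.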